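Swapping Bromo for Methyl on a Thioether Aryl Ring

The compounds below may be only part of what the source reports. "The series", "measured", "known", "first", "only" and "open" are said of these compounds alone.

Going by the values given here, compound 3 `Nc1ccccc1NC(=O)c1ccc(CSc2ccc(Br)cc2)cc1` gives 67.7% in a functional assay on HCT-116 cells (Homo sapiens) for inhibition, read by CCK-8 assay, with a stated time of 72 h, tested at 8 uM (a lower number here means less inhibition of growth, a higher number more inhibition of growth at the concentration tested), the highest of the three numbers measured so far. Compound 2 `COc1ccc(SCc2ccc(/C=C/C(=O)Nc3ccccc3N)cc2)cc1OC` comes next with 49.5%, and compound 1 `Cc1ccc(SCc2ccc(/C=C/C(=O)Nc3ccccc3N)cc2)cc1` stands furthest away with 4.93%; both gaps lie beyond the scatter. Compound 4 `Cc1ccc(SCc2ccc(C(=O)Nc3ccccc3N)cc2)cc1` has not yet been measured. It differs from compound 3 in one place: methyl in place of bromo on an aromatic carbon, on an aromatic carbon of a six-membered aromatic ring of carbon only, para to a large group. Among the compounds with values here, no measured step exchanges bromo for methyl directly. Within the data shown here, the one measured step, a number 44.6 percentage points higher from compound 1 to compound 2 (beyond the scatter), shows that the group on the ring attached to the sulfur can shift the number a long way, and compound 1, the only measured compound carrying 4-methylphenyl on the sulfur, sits lowest of all. For compound 4 a downward step is therefore expected, a number 32.7 percentage points lower from compound 3 to compound 4 (beyond the scatter), though its size is uncertain. Compound 4 is estimated at 35%, within 5% to 65%.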

Compound 4, percent growth inhibition at one concentration: 84%
Estimate against measurement, compound 4: 49 percentage points below, and the stated range ends below it.
By their numbers in this assay, from the lowest: compound 1; then compound 2; then compound 3; then compound 4.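

In this assay, going by these compounds alone, methyl in place of bromo gives a number 16.3 percentage points higher from compound 3 to compound 4 (beyond the scatter), so 4-methylphenyl on the sulfur does not by itself go with a low number, even though the only earlier compound carrying it, compound 1, gives 4.93%. Compound 4 carries the same 4-methylphenyl group and gives 84%, and it differs from compound 1 by lacking the carbon-carbon double bond in the link to the amide carbonyl, so the reading of this group depends on the rest of the molecule. Nothing measured here explains why the methyl compound stands higher.

Going by these compounds, how an amine or a carboxylic acid at this place would compare remains open. On these data alone, it is also open whether 3,4-dimethoxyphenyl on the sulfur would raise the number in the core of compound 4 as it does in the core of compound 1.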